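The source may hold more compounds than are shown below. What is called first, only, known or untested is meant among the compounds shown, and "the series" means these compounds.

Of the compounds shown here, three of one shared core have been measured for their ability to stop the growth of a human prostate cancer cell line. Compound 1 `COc1ccc(CS(=O)(=O)/C=C/c2ccc(F)cc2OC)cc1` gives 10000 nM in a functional assay on DU-145 cells (Homo sapiens) for antiproliferative activity, read by trypan blue exclusion; on this read-out lower numbers stand for stronger inhibition and higher numbers for weaker inhibition. Compound 2 `COc1ccc(CS(=O)(=O)/C=C/c2c(OC)cccc2OC)cc1` gives 250 nM in this assay. Compound 3 `COc1ccc(CS(=O)(=O)/C=C/c2c(OC)cc(OC)cc2OC)cc1` gives 25 nM in this assay, the lowest of the three numbers; the nearest is compound 2 and the furthest is compound 1.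

Compound 4 `COc1ccc(CS(=O)(=O)/C=C/c2c(OC)cc(F)cc2OC)cc1` differs from compound 3 in one place: fluoro in place of methoxy on an aromatic carbon, at the carbon that is meta to two methoxy groups and para to a large group. Going by the values given here, no measured step swaps fluoro for methoxy. The step that bears on the same position is a 10-fold lower number from compound 2 to compound 3 (1.00 log units; beyond the scatter), where the methoxy entered in place of hydrogen. Taking that methoxy away again is therefore expected to raise the number, and a fluoro there is expected to sit somewhere between hydrogen and methoxy, so a modest step upward is expected, a 4.8-fold higher number from compound 3 to compound 4 (0.68 log units; beyond the scatter). Compound 4 is thus estimated at 120 nM in this assay, within a range from 35 nM to 500 nM.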

Compound 4, half-maximal inhibitory concentration: 500 nM
The estimate for compound 4 lay 4.2-fold (0.62 log units) below the measured number, and the stated range covers the measured number.
By their numbers in this assay, from the lowest: compound 3; then compounds 2 and 4 (each within the scatter of the next); then compound 1.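

Fluoro does not stand in for methoxy at this carbon, the one para to a large group: the swap gives a 20-fold higher number from compound 3 to compound 4 (1.30 log units; beyond the scatter). Fluoro in place of hydrogen gives a 2.0-fold higher number from compound 2 to compound 4 (0.30 log units; within the scatter), so fluoro and hydrogen cannot be told apart here, and the low number of compound 3 goes with the methoxy itself rather than with having any group on that carbon. Methoxy in place of hydrogen at another carbon of the same ring, on a core that carries the fluoro, gives a 20-fold lower number from compound 1 to compound 4 (1.30 log units; beyond the scatter), so the earlier step now has a counterpart: the same change on two cores in this assay, a 10-fold lower number (1.00 log units; beyond the scatter) from compound 2 to compound 3 and a 20-fold lower number (1.30 log units; beyond the scatter) from compound 1 to compound 4, 2.0-fold (0.30 log units) apart, within the scatter of two such steps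

As far as these compounds go, whether only methoxy keeps the number low at this carbon remains open, since a hydroxyl, an amine or a longer chain such as ethoxy could do the same. The compounds shown also leave open whether chloro would track with fluoro and hydrogen in this assay.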